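Removing the anilino group from compound 3

A few compounds are considered here, and "the series" means these few. Any claim that something is new, unique, unknown or untested is made for them only; others in the source may bear on it.

Three related compounds have been run in a functional assay on A549 cells (Homo sapiens) for antiproliferative activity, read by spectrophotometry, with a stated time of 2 days (on this read-out higher numbers stand for weaker inhibition of growth and lower numbers for stronger inhibition of growth), so far. Compound 1 (`COc1ccc(Nc2ncc(C(F)(F)F)c(N3Cc4cccc(N(C)S(C)(=O)=O)c4C3)n2)cc1C(F)(F)F`) gives > 30000 nM as a limit of the assay, not a number. Compound 2 (`Cc1ccc(Nc2ncc(C(F)(F)F)c(N3Cc4cccc(N(C)S(C)(=O)=O)c4C3)n2)c(Cl)c1`) gives > 30000 nM as a limit too. Among the compounds with values here, compound 3 (`CN(c1cccc2c1CN(c1nc(Nc3ccc(Nc4ccccc4)cc3)ncc1C(F)(F)F)C2)S(C)(=O)=O`) gives 6200 nM as the only actual number among the three.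

Compound 4 (`CN(c1cccc2c1CN(c1nc(Nc3ccc(C(F)(F)F)cc3)ncc1C(F)(F)F)C2)S(C)(=O)=O`) differs from compound 3 in one place, with trifluoromethyl in place of anilino on an aromatic carbon. Within the data shown here, the single measured step (a step that the two limits leave unreadable from compound 1 to compound 2) has no readable size, so it offers no guide to the size of this change. The closer guide is the limit of > 30000 nM in this assay, at which 2 of the 3 values shown sit, and compound 1 and compound 2 both lack the anilino group. Compound 3 at 6200 nM is the only one of the three that carries it, so compound 4 is expected to inhibit growth more weakly, although three compounds are thin support. The expected step is a 4.5-fold higher number from compound 3 to compound 4 (0.65 log units; beyond the scatter) in this assay as an estimate beyond the usual scatter. Compound 4 is estimated at 28000 nM within a range from 10000 nM to 70000 nM and may well return only a limit.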

Compound 4, concentration for 50% growth inhibition: > 30000 nM
Compound 4 was reported as a limit; the forecaster's own chance of this, stated with the estimate: 60%; middle value at least 1.0-fold (0.02 log units) away from the limit.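

Within the data shown here, at this position, on an aromatic carbon para to a large group, the earlier compounds offered only a hint that anilino mattered, with no step of readable size. In this assay, this single change of anilino to trifluoromethyl now gives a readable step, an at least 4.8-fold higher number from compound 3 to compound 4 (0.68 log units; beyond the scatter), which shows that a change at this one place is enough to weaken growth inhibition beyond the usual scatter. The value of compound 4 is a limit, and its steps to compound 1 and compound 2 cannot be read, so this result places compound 4 with the other compounds at the same limit: the limit of > 30000 nM in this assay, at which 3 of the 4 values shown sit.

The compounds shown leave open whether the outer benzene ring of anilino or its linking nitrogen matters more, since trifluoromethyl replaces both at once. A phenoxy group, which keeps a ring but swaps the nitrogen for oxygen, or a simple amino group, which keeps the nitrogen without the ring, would help to separate the two at this position.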